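Acetyl for dimethylamino on two related cores

The source may hold more compounds than are shown below. What is called first, only, known or untested is meant among the compounds shown, and "the series" means these compounds.

The study compares three measured compounds and one that awaits measurement in an assay on isolated protein for binding affinity to corticotropin-releasing factor receptor 1 (Homo sapiens); a higher number here means a weaker inhibitor, a lower number a stronger inhibitor. Compound 1 `CCN(CC)c1nc(C)nc(N(CC)c2ccc(N(C)C)cc2Br)n1` gives 6 nM. Compound 2 `CCN(CC)c1cc(C)nc(N(CC)c2ccc(N(C)C)cc2Br)n1` gives 27 nM, and compound 3 `CCN(CC)c1cc(C)nc(N(CC)c2ccc(C(C)=O)cc2Br)n1` gives 5 nM. Compound 1 and compound 2 carry different cores; the difference between the two cores is not broken down here.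

From compound 2 to compound 3 the change is acetyl in place of dimethylamino on an aromatic carbon. This step gave a 5.4-fold lower number from compound 2 to compound 3 (0.73 log units; beyond the scatter). The same change is now made on the core of compound 1: compound 4 `CCN(CC)c1nc(C)nc(N(CC)c2ccc(C(C)=O)cc2Br)n1` differs from compound 1 by acetyl in place of dimethylamino on an aromatic carbon, and this change occurs twice among the compounds shown.

Going by the values given here, for compound 4 the author expects a step of about a 3.0-fold lower number from compound 1 to compound 4 (0.48 log units; beyond the scatter), set beside the earlier one, resting on the single measured pair, compound 2 to compound 3 with a 5.4-fold lower number from compound 2 to compound 3 (0.73 log units; beyond the scatter), and on the starting value of compound 1 at 6 nM. The estimate for compound 4 in this assay is therefore 2 nM, with a range from 0.7 nM to 6 nM.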

Compound 4, inhibition constant: 17 nM
Beside the measured number, compound 4's estimate is 8.5-fold (0.93 log units) below it, outside the stated range (above it).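

On the core of compound 1, acetyl in place of dimethylamino on an aromatic carbon runs the other way in this assay, with a 2.8-fold higher number from compound 1 to compound 4 (0.45 log units; beyond the scatter), so the direction of the earlier step did not carry over. The two steps point in opposite directions, and the gap between them is larger than the usual scatter of two such steps: the same change on two cores in this assay, a 5.4-fold lower number (0.73 log units; beyond the scatter) from compound 2 to compound 3 and a 2.8-fold higher number (0.45 log units; beyond the scatter) from compound 1 to compound 4, 15-fold (1.18 log units) apart, beyond the scatter of two such steps. Going by these compounds alone, in these compounds the result of the change therefore depends on the core that carries it, but this rests on only two pairs and does not show which feature of the cores is responsible or how the change would behave on a further core.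

The compounds shown leave open whether a longer ketone such as propanoyl, or a methoxy group or a nitrile, on the same aromatic carbon would also follow the core in this way. They also leave open whether the reversal persists when the bromo group is replaced by a chloro group.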